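Triazolopyrimidine series: sulfanyl-linked group varied, growth inhibition

A few compounds are considered here, and "the series" means these few. Any claim that something is new, unique, unknown or untested is made for them only; others in the source may bear on it.

Measured so far:
compound 1, `Cc1cc(Nc2cc(-c3ccccc3)[nH]n2)n2nc(SCc3nc4ccccc4[nH]3)nc2n1`: 4840 nM
compound 2, `Cc1cc(Nc2cc(-c3ccc(F)cc3)[nH]n2)n2nc(SCc3ccc(Br)cc3)nc2n1`: 6210 nM

In a functional assay on PC-9 cells (Homo sapiens) for inhibition, read by MTT assay, with a stated time of 72 h (on this read-out higher numbers stand for weaker inhibition and lower numbers for stronger inhibition), compound 1 gives 4840 nM and compound 2 gives 6210 nM; the two numbers lie within the usual scatter of each other, so compound 1 sits alongside compound 2 with no separation between them. For the measured compounds named here, no pair of measured compounds differs in a single place, so no step has been quantified.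

Compound 3, `COc1ccc(CSc2nc3nc(C)cc(Nc4cc(-c5ccccc5)[nH]n4)n3n2)cc1`, is yet to be measured in this assay. Relative to compound 1 the change is 4-methoxyphenyl in place of 1H-benzimidazol-2-yl on a saturated chain carbon bound to a sulfur. Compound 2, which also carries a substituted benzyl group on the sulfur, gives 6210 nM, so a benzyl group on the sulfur is not expected to move the number beyond the scatter in either direction. The expected step of a 1.1-fold higher number from compound 1 to compound 3 (0.06 log units; within the scatter) is therefore small. Compound 3 is estimated at 5500 nM, with a range from 2500 nM to 12000 nM.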

Compound 3, half-maximal inhibitory concentration: 8110 nM
For compound 3 the middle estimate is 1.5-fold (0.17 log units) below the measured one; low and high end bracket the measured number.
By their numbers in this assay, from the lowest: compounds 1, 2 and 3 (each within the scatter of the next).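

For the compounds shown here, this is the first measured step at this position. In this assay, 4-methoxyphenyl in place of 1H-benzimidazol-2-yl on a saturated chain carbon bound to a sulfur gives a 1.7-fold higher number from compound 1 to compound 3 (0.22 log units; within the scatter), so this pair shows that the five-membered aromatic ring and the hydrogen-bond donor of 1H-benzimidazol-2-yl can leave without the number moving beyond the scatter. No measurement at hand explains the size of this step.

Still open, on these data alone, is whether any group at this place separates from compound 1 in this read-out. A carboxylic acid or an amine in place of 4-methoxyphenyl, or a longer chain on the sulfur, would test whether this position responds to larger changes than the one seen here.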